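This account rests on a few compounds, and the source may have more. Where it says the series, first, only, none or still open, it means among the compounds named here.

Measured compounds: compound 1 `Cc1ccncc1OC[C@@H]1CCCN1C`, 4.12 nM; compound 2 `CN1CCC[C@H]1COc1cnccc1Br`, 28 nM; compound 3 `CN1CCC[C@H]1COc1cncc(Br)c1`, 0.27 nM.

In an assay on membranes from brain for displacement of a labelled ligand from Neuronal acetylcholine receptor; alpha4/beta2 (Rattus norvegicus) (a higher number here means a weaker inhibitor, a lower number a stronger inhibitor), compound 3 gives the lowest number of the three. Compound 3 and compound 2 have the same atoms joined differently; the difference between the two cores is not broken down here. From compound 2 to compound 1 the change is methyl in place of bromo on an aromatic carbon, and it gave a 6.8-fold lower number from compound 2 to compound 1 (0.83 log units; beyond the scatter). Compound 4 `Cc1cncc(OC[C@@H]2CCCN2C)c1` has not yet been measured in this assay; it arises from compound 3 by methyl in place of bromo on an aromatic carbon. This is the same kind of change, not the same: in compound 2 the bromo is ortho to a group of 8 heavy atoms and opposite the ring nitrogen, whereas in compound 3 it is two atoms from the ring nitrogen and meta to a group of 8 heavy atoms. Resting on a 6.8-fold lower number from compound 2 to compound 1 (0.83 log units; beyond the scatter) but with the place changed, compound 4 is expected to show a 1.5-fold higher number from compound 3 to compound 4 (0.17 log units; within the scatter). Compound 4 is therefore estimated at 0.4 nM, between 0.1 nM and 1.5 nM.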

Compound 4, inhibition constant: 0.48 nM
Estimate against measurement, compound 4: 1.2-fold (0.08 log units) below, within the range that was stated.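

In this assay, methyl in place of bromo on an aromatic carbon gives a 1.8-fold higher number from compound 3 to compound 4 (0.25 log units; within the scatter), a step that cannot be told apart from repeat measurement. Set beside the earlier step, the same change does not carry over from one core to the other with the same size: the same change on two cores in this assay, a 6.8-fold lower number (0.83 log units; beyond the scatter) from compound 2 to compound 1 and a 1.8-fold higher number (0.25 log units; within the scatter) from compound 3 to compound 4, 12-fold (1.08 log units) apart, beyond the scatter of two such steps. Among the compounds shown here, this shows that the effect of this change cannot be transferred between these two cores, but with only two pairs it does not show what sets the difference, nor how the change would behave on any other core.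

The compounds shown leave open how other groups, such as chloro, a nitrile or an amine, would read at the place two atoms from the ring nitrogen. They also leave open whether a longer chain there would follow methyl or bromo.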